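A few compounds are considered here, and "the series" means these few. Any claim that something is new, unique, unknown or untested is made for them only; others in the source may bear on it.

The series shares one core; compound 1 `O=C(O)CCC(=O)N1N=C(c2c(-c3ccccc3)c3cc(Cl)ccc3[nH]c2=O)CC1c1ccc(F)cc1`, compound 2 `O=C(O)CCC(=O)N1N=C(c2c(-c3ccccc3)c3cc(Cl)ccc3[nH]c2=O)CC1c1ccc(Br)cc1` and compound 3 `O=C(O)CCC(=O)N1N=C(c2c(-c3ccccc3)c3cc(Cl)ccc3[nH]c2=O)CC1c1ccc([N+](=O)[O-])cc1` differ only in the group carried on the aromatic ring of the saturated ring system. In an assay on cells (Oocyte) for negative allosteric modulation of glutamate receptor ionotropic, NMDA 2D (Rattus norvegicus), read by two-electrode voltage clamp (on this read-out higher numbers stand for weaker inhibition and lower numbers for stronger inhibition), compound 1 gives 14000 nM, compound 2 gives 3100 nM and compound 3 gives 1100 nM. The steps run a 4.5-fold lower number from compound 1 to compound 2 (0.65 log units; beyond the scatter), a 13-fold lower number from compound 1 to compound 3 (1.10 log units; beyond the scatter) and a 2.8-fold lower number from compound 2 to compound 3 (0.45 log units; beyond the scatter), so compound 3 stands lowest of the three numbers, beyond the scatter from both other compounds.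

Compound 4 `O=C(O)CCCC(=O)N1N=C(c2c(-c3ccccc3)c3cc(Cl)ccc3[nH]c2=O)CC1c1ccc([N+](=O)[O-])cc1` keeps the nitro group of compound 3 and alters the chain on the carbonyl: carboxymethyl in place of carboxy on a saturated chain carbon, two bonds along the chain from a carbonyl carbon; read one bond further out, this is (2-carboxyethyl)carbonyl to (3-carboxypropyl)carbonyl. Within the data shown here, none of the measured steps touches this chain, as all three concern the group on the aromatic carbon, so no measured step bears on this change. In this assay compound 4 is therefore expected near compound 3, estimated at 1100 nM with a range from 400 nM to 3500 nM. The step this estimate means, no change at the digits printed from compound 3 to compound 4 (within the scatter), is expected to lie within the scatter, in no set direction.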

Compound 4, half-maximal inhibitory concentration: 11000 nM
Compound 4: middle estimate off by 10-fold (1.00 log units), on the low side; the whole stated range lies below it.
By their numbers in this assay, from the lowest: compound 3; then compound 2; then compounds 4 and 1 (each within the scatter of the next).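

The chain on the carbonyl is a sensitive place in this series: with nitro held on the aromatic carbon, (3-carboxypropyl)carbonyl in place of (2-carboxyethyl)carbonyl gives a 10-fold higher number from compound 3 to compound 4 (1.00 log units; beyond the scatter) in this assay, towards weaker inhibition. Among these compounds, the earlier steps concerned only the group on the aromatic carbon, so this is the first sign that the chain carrying the carboxy group also moves the read-out beyond the scatter. Nothing available explains this step.

Open, on these data alone, is how a shorter or still longer chain would read at this place, or a methyl ester or primary amide in place of the terminal carboxylic acid. Also open, as far as these compounds go, is whether the (3-carboxypropyl)carbonyl chain gives a step of similar size with fluoro or bromo in place of nitro.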